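The source may report more compounds than this note shows. Statements on the series, on what has been measured and on what is new or still open speak of the compounds shown alone.

Measured compounds in a functional assay on the whole organism (strain Sprague-Dawley CD) for inhibition, with Rattus norvegicus as the target, read by paw edema, at a dose of 30 mg/kg by the oral route; on this read-out higher numbers stand for a stronger effect at the one dose given and lower numbers for a weaker effect:
- compound 1 `CCOC(=O)C(=O)Nc1ccccc(C)c1=O`: 6%
- compound 2 `CCOC(=O)C(=O)Nc1cccc(OC)cc1=O`: 45%
- compound 3 `CC(C)OC(=O)C(=O)Nc1cccccc1=O`: 63%

Among these three, compound 3 gives the highest number in this assay; compound 2 sits a step below it, and compound 1 sits far below, both gaps beyond the usual scatter. Compound 4 `CCCCCOC(=O)C(=O)Nc1cccccc1=O` has not yet been measured. It differs from compound 3 in one place: pentyl in place of isopropyl on an oxygen next to a carbonyl group. Going by the values given here, no two measured compounds differ only in the size of this chain, so there is nothing to show how such a change plays out. The step of a number 13 percentage points lower from compound 3 to compound 4 (beyond the scatter) is therefore expected to be modest, most likely downward or within the scatter. For compound 4, the value in this assay is estimated at 50%, within a range from 25% to 75%.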

Compound 4, a percentage reported as inhibition, in the whole organism at one dose (the size of the read-out at that dose, not a potency): 12%
For compound 4 the middle estimate is 38 percentage points above the measured one; the whole stated range lies above it.
By their numbers in this assay, from the lowest: compounds 1 and 4 (each within the scatter of the next); then compound 2; then compound 3.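

In this assay, going by these compounds alone, the chain on an oxygen next to a carbonyl group proves to matter: pentyl in place of isopropyl gives a number 51 percentage points lower from compound 3 to compound 4 (beyond the scatter), the only single-place comparison available here. A change in this chain alone can therefore remove much of the effect seen at the one dose given. Nothing measured here bears on why the step is so large.

As far as these compounds go, whether a propyl or butyl chain on this oxygen would sit nearer compound 3 or compound 4 remains open. From the compounds shown here alone, what a benzyl group would do there is equally open.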